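This account rests on a few compounds, and the source may have more. Where it says the series, first, only, none or still open, it means among the compounds named here.

Measured so far:
compound 1 `CC(C)CCN1C(=O)C(C2=NS(=O)(=O)c3cc(NS(C)(=O)=O)ccc3N2)=C(O)C2CCCC21`: > 1000 nM
compound 2 `CC(C)CCN1C(=O)C(C2=NS(=O)(=O)c3cc(NS(C)(=O)=O)ccc3N2)=C(O)[C@H]2CCC[C@H]21`: > 1000 nM

In an ADME assay on Huh-7 cells (Homo sapiens) for cytotoxicity, with a stated time of 72 h (a higher number here means that more compound is tolerated, a lower number that less compound is tolerated), compound 1 gives > 1000 nM, a limit of the assay rather than a number. In this assay compound 2 gives > 1000 nM, likewise a limit. The step that the two limits leave unreadable from compound 1 to compound 2 cannot be read because of the limit of > 1000 nM in this assay, at which 2 of the 2 values shown sit. Compound 2 thus stands at the assay limit, indistinguishable from compound 1 on the numbers shown.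

Compound 3 `CS(=O)(=O)Nc1ccc2c(c1)S(=O)(=O)N=C(C1=C(O)[C@H]3CCC[C@H]3N(Cc3cccc(C(F)(F)F)c3)C1=O)N2` carries 3-(trifluoromethyl)phenyl in place of isobutyl on a saturated chain carbon bound to an amide-type nitrogen in a ring. Among the measured compounds shown here, no measured step bears on this change; the only measured step concerns drawn stereochemistry and is itself unreadable. Compound 3 is therefore expected to sit again at or beyond the limit, estimated at 2000 nM (range 600 nM to 8000 nM). The expected step that the limit leaves unreadable from compound 2 to compound 3 is uncertain in size and direction.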

Compound 3, half-maximal cytotoxic concentration: > 33000 nM
Compound 3: a limit, no number; the forecaster's own chance of this, stated with the estimate: 75%; at least 16-fold (1.21 log units) between middle value and limit.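

The step from compound 2 to compound 3 in this assay cannot be read, as both values are limits and not numbers. Still open, as far as these compounds go, is where compound 2 and compound 3 truly lie, and whether 3-(trifluoromethyl)phenyl in place of isobutyl shifts the read-out at all.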